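Cytotoxicity of a Small Series on Human MT4 Cells

This account rests on a few compounds, and the source may have more. Where it says the series, first, only, none or still open, it means among the compounds named here.

Measured compounds:
- Compound 1, `Cc1ccc(NC(=O)CSc2snnc2-c2ccccc2)c(Br)c1`: > 297000 nM
- Compound 2, `COc1ccc(-c2nnsc2SCC(=O)Nc2ccc(C)cc2Br)cc1`: 249000 nM
- Compound 3, `COc1ccc(-c2nnsc2SCC(=O)Nc2ccccc2Br)cc1`: > 286000 nM

All three were tested in an ADME assay on MT4 cells (Homo sapiens) for cytotoxicity; on this read-out higher numbers stand for lower toxicity in this test and lower numbers for higher toxicity in this test. Compound 2 gives a number, 249000 nM. For compound 1 the figure > 297000 nM is a limit of the assay and not a number. For compound 3 the figure > 286000 nM is likewise a limit of the assay and not a number.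

The step from compound 2 to compound 1 is hydrogen in place of methoxy on an aromatic carbon. In this assay it made an at least 1.1-fold higher number from compound 2 to compound 1 (0.07 log units; that floor lies within the scatter), a floor set by the limit of > 297000 nM in this assay, at which 1 of the 3 values shown sits.

The cores of compound 2 and compound 3 differ by hydrogen in place of methyl on an aromatic carbon, and that step gave an at least 1.1-fold higher number from compound 2 to compound 3 (0.06 log units; that floor lies within the scatter), resting on (the limit of > 286000 nM in this assay, at which 1 of the 3 values shown sits).

Compound 4, `O=C(CSc1snnc1-c1ccccc1)Nc1ccccc1Br`, is not yet measured. For the measured compounds named here, it differs from compound 3 by hydrogen in place of methoxy on an aromatic carbon, the same change as the one from compound 2 to compound 1, at a place described in the same words. Because the earlier step gave an at least 1.1-fold higher number from compound 2 to compound 1 (0.07 log units; that floor lies within the scatter) with the result sitting at the limit of > 297000 nM in this assay, at which 1 of the 3 values shown sits, compound 4 is expected to stay at the top of the range as well, with an estimated step that the limit leaves unreadable from compound 3 to compound 4. The estimate for compound 4 is 300000 nM, between 150000 nM and 600000 nM, most likely reported only as a limit.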

Compound 4, half-maximal cytotoxic concentration: > 307000 nM
Compound 4: only a limit was reported; the forecaster's own chance of this, stated with the estimate: 80%; middle value at least 1.0-fold (0.01 log units) away from the limit.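

In this assay compound 4 gives > 307000 nM, which is a limit of the assay and not a number. Compound 1 and compound 3 also carry limits, and the steps from each of them to compound 4 cannot be read. The compounds shown leave open how far these three compounds lie from one another, and whether hydrogen in place of methoxy or methyl changes the read-out at all.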